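The compounds below may be only part of what the source reports. "The series", "measured", "known", "first", "only" and "open" are said of these compounds alone.

Measured in an ADME assay on HEK293 cells (Homo sapiens) for cytotoxicity, read by CCK-8 assay, with a stated time of 4 days; on this read-out lower numbers stand for stronger inhibition and higher numbers for weaker inhibition:
Compound 1 `Oc1ccc(-c2cc(-c3cccc(O)c3)nc(-c3cccc(O)c3)c2)cc1`: 730 nM
Compound 2 `Oc1cccc(-c2cc(-c3cccc(O)c3)nc(-c3cccc(O)c3)c2)c1`: 740 nM

Only these two compounds have numbers in this assay, and compound 1 stands level with compound 2: the step between them is a 1.0-fold higher number from compound 1 to compound 2 (0.01 log units; within the scatter). Compound 3 `Oc1ccc(-c2cc(-c3cccc(O)c3)nc(-c3ccccc3O)c2)cc1` has the same atoms as compound 1, joined differently: 2-hydroxyphenyl in place of 3-hydroxyphenyl on an aromatic carbon. A 2-hydroxyphenyl takes the place of a 3-hydroxyphenyl on an aromatic carbon next to the ring nitrogen, while the 4-hydroxyphenyl group stays.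

For the measured compounds named here, one measured step bears on this change, and only indirectly. It also moves a hydroxyl around a phenyl group, but at a different place on the core, and it amounts to a 1.0-fold higher number from compound 1 to compound 2 (0.01 log units; within the scatter). Going by the values given here, no measured compound carries a 2-hydroxyphenyl group, so the data do not test this particular swap. On that single precedent, no shift beyond the scatter is expected, and the range is kept wide. The expected result is a 1.1-fold higher number from compound 1 to compound 3 (0.04 log units; within the scatter). Compound 3 is estimated at 800 nM, with an expected range from 300 nM to 2200 nM.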

Compound 3, half-maximal inhibitory concentration: 7420 nM
The estimate for compound 3 lay 9.3-fold (0.97 log units) below the measured number; the measured number lies above the stated range.
By their numbers in this assay, from the lowest: compounds 1 and 2 (each within the scatter of the next); then compound 3.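

In this assay, the change from 3-hydroxyphenyl to 2-hydroxyphenyl on the aromatic carbon next to the ring nitrogen gives a 10-fold higher number from compound 1 to compound 3 (1.01 log units; beyond the scatter), a large step to weaker inhibition. The groups that leave and enter have identical heavy-atom, donor and acceptor counts, so this read-out distinguishes between two arrangements of the same atoms at this position, whereas the hydroxyl shift elsewhere on the core gives a 1.0-fold higher number from compound 1 to compound 2 (0.01 log units; within the scatter), which lies within the scatter. The shared core therefore does not tolerate every hydroxyl shift equally in this assay, although one step at each of two places supports no general rule, and no available measurement accounts for the difference.

From the compounds shown here alone, it remains open whether the hydroxyl itself matters at this position, which a methoxy group in its place or a phenyl group carrying no hydroxyl would help to show. Going by these compounds, it is also open whether a 2-hydroxyphenyl group in place of the 4-hydroxyphenyl group, or an amine in place of the hydroxyl on the 2-substituted ring, would give a similar step.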